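The compounds below may be only part of what the source reports. "The series", "measured", "known", "first", "only" and "open" are said of these compounds alone.

Working notes on the series. Compound 1 `CCOc1cc(C)c(-c2cccc(CNc3ccc(OCC(=O)O)c(F)c3)c2)c(C)c1` gives 24.2 nM in a functional assay on CHO cells for agonist activity at Free fatty acid receptor 1 (Homo sapiens), read by FLIPR and calcium flux (a higher number here means that more compound is needed for the effect, a lower number that less compound is needed), and compound 2 `Cc1cc(OCCCS(C)(=O)=O)cc(C)c1-c1cccc(CNc2ccc(OCC(=O)O)c(F)c2)c1` gives 59.8 nM. Within the data shown here, of the two numbers measured so far, compound 2 stands highest, the only step being a 2.5-fold higher number from compound 1 to compound 2 (0.39 log units; beyond the scatter). Compound 3 `Cc1cc(OCCCS(C)(=O)=O)ccc1-c1cccc(CNc2ccc(OCC(=O)O)c(F)c2)c1` is not yet measured; it differs from compound 2 by hydrogen in place of methyl on an aromatic carbon. Among the measured compounds shown here, no measured step touches this position: the one step known, from compound 1 to compound 2, concerns the chain on the other ring of the shared core, so it offers no direct guide. The expectation therefore rests on the change itself and on compound 2 alone; a step about the size of a 1.8-fold higher number from compound 2 to compound 3 (0.26 log units; within the scatter) toward a higher number is expected, but with wide uncertainty. Compound 3 is estimated at 110 nM, with a range from 40 nM to 320 nM.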

Compound 3, half-maximal effective concentration: 45.6 nM
Compound 3: the middle estimate sits 2.4-fold (0.38 log units) above what was measured, within the range that was stated.
By their numbers in this assay, from the lowest: compounds 1, 3 and 2 (each within the scatter of the next, the first and the last beyond it).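

Hydrogen in place of methyl on this aromatic carbon, ortho to a large group, gives a 1.3-fold lower number from compound 2 to compound 3 (0.12 log units; within the scatter) in this assay. With the 3-(methylsulfonyl)propoxy group held constant, this methyl can therefore be exchanged for hydrogen without a step beyond the scatter, something compounds 1 and 2 could not show, as both carry methyl at this carbon. Nothing measured on these compounds speaks to the reason for this result.

The compounds shown leave open whether a chlorine, a methoxy or an ethyl group on this carbon would give a step beyond the scatter, and whether hydrogen in place of the remaining methyl would do so. Also open, going by these compounds, is whether the same exchange in compound 1 would give a step of similar size.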